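Aryl exchange on the aromatic nitrogen of compound 1

This account rests on a few compounds, and the source may have more. Where it says the series, first, only, none or still open, it means among the compounds named here.

- compound 1 `COc1cc(C(=O)c2cn(-c3cccc(C)c3)cc2-c2ccccc2Cl)cc(OC)c1OC` gives 420 nM
- compound 2 `COc1cc(C(=O)c2cn(-c3cccc(C)c3)cc2-c2cccc(N)c2)cc(OC)c1OC` gives 130 nM

In a functional assay on MCF7 cells (Homo sapiens) for cytotoxicity, read by MTT assay, with a stated time of 96 h (on this read-out lower numbers stand for stronger inhibition and higher numbers for weaker inhibition), compound 1 stands highest of the two measured compounds, at 420 nM. Among the compounds with values here, the only measured step is a 3.2-fold lower number from compound 1 to compound 2 (0.51 log units; beyond the scatter), a modest one that lies beyond the scatter.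

Compound 3 `COc1cc(C(=O)c2cn(-c3ccc(F)cc3)cc2-c2ccccc2Cl)cc(OC)c1OC` keeps the 2-chlorophenyl group of compound 1 and differs elsewhere: 4-fluorophenyl in place of 3-methylphenyl on an aromatic nitrogen. This places 4-fluorophenyl in place of 3-methylphenyl on an aromatic nitrogen.

That measured step replaced the 2-chlorophenyl group and left this nitrogen untouched, so it gives no direct size for the present change. No step beyond the scatter is therefore expected in this assay, in either direction, though the data cannot exclude one. The expected step is a 1.1-fold lower number from compound 1 to compound 3 (0.02 log units; within the scatter). For compound 3 the estimated value is 400 nM, with an expected range from 150 nM to 1100 nM.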

Compound 3, half-maximal inhibitory concentration: 83 nM
The estimate for compound 3 lay 4.8-fold (0.68 log units) above the measured number; measured number outside the range, below it.
By their numbers in this assay, from the lowest: compounds 3 and 2 (each within the scatter of the next); then compound 1.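

In this assay the aryl group on the aromatic nitrogen turns out to be a position that responds: with the 2-chlorophenyl group held constant, 4-fluorophenyl in place of 3-methylphenyl gives a 5.1-fold lower number from compound 1 to compound 3 (0.70 log units; beyond the scatter) in a single exchange. Until this result, only the exchange of the 2-chlorophenyl group had shown a step beyond the scatter, so the series now has two places that move the number. The leaving and entering groups match in heavy-atom count and carry no hydrogen-bond donors or acceptors, and no measurement on hand accounts for the step.

Still open, from the compounds shown here alone, is whether the step follows from gaining the fluorine or losing the methyl, as the exchange does both at once. Also open, going by these compounds, is how a carboxylic acid or a longer alkyl chain on the aromatic nitrogen would read, and whether 4-fluorophenyl and 3-aminophenyl together on the shared core would add up.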